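A Fluorine on the Phenyl of Compound 3

The source may report more compounds than this note shows. Statements on the series, on what has been measured and on what is new or still open speak of the compounds shown alone.

Compound 3 `CN1C(=O)C(c2ccccc2)N(C)c2nc(Nc3ccc(S(N)(=O)=O)cc3)ncc21` gives 383 nM in an assay on Sf9 cells for inhibition of serine/threonine-protein kinase 4 (Homo sapiens), read by luminescence and ADP-Glo, with a stated time of 1 h, in the presence of a further agent that is not named here; a higher number here means a weaker inhibitor, a lower number a stronger inhibitor. It stands second highest of three numbers: compound 1 `CC1C(=O)N(C)c2cnc(Nc3ccc(S(N)(=O)=O)cc3)nc2N1C` gives 313 nM, the nearest, and compound 2 `CCC1C(=O)N(C)c2cnc(Nc3ccc(S(N)(=O)=O)cc3)nc2N1C` gives 479 nM, the furthest. The steps of a 1.2-fold higher number from compound 1 to compound 3 (0.09 log units; within the scatter) and a 1.3-fold lower number from compound 2 to compound 3 (0.10 log units; within the scatter) both lie within the scatter, as does a 1.5-fold higher number from compound 1 to compound 2 (0.18 log units; within the scatter). Compound 4 `CN1C(=O)C(c2cccc(F)c2)N(C)c2nc(Nc3ccc(S(N)(=O)=O)cc3)ncc21` differs from compound 3 by fluoro in place of hydrogen on an aromatic carbon. Within the data shown here, none of the measured steps touches the phenyl itself; all three vary the group on the saturated ring carbon, and none moves the number beyond the scatter. Compound 4 is therefore expected to show no step beyond the scatter, a 1.0-fold lower number from compound 3 to compound 4 (0.00 log units; within the scatter). The estimate for compound 4 is 380 nM, with a range from 190 nM to 760 nM.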

Compound 4, half-maximal inhibitory concentration: 134 nM
Beside the measured number, compound 4's estimate is 2.8-fold (0.45 log units) above it; measured number outside the range, below it.
By their numbers in this assay, from the lowest: compound 4; then compounds 1, 3 and 2 (each within the scatter of the next).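

Unlike the earlier swaps on the saturated ring carbon, all within the scatter, a change on the phenyl itself moves the number in this assay (a 2.9-fold lower number from compound 3 to compound 4 (0.46 log units; beyond the scatter)). The 3-fluorophenyl group also stands apart from ethyl (a 3.6-fold lower number from compound 2 to compound 4 (0.55 log units; beyond the scatter)) and methyl (a 2.3-fold lower number from compound 1 to compound 4 (0.37 log units; beyond the scatter)), making compound 4 the strongest inhibitor of the four. No measured evidence bears on this gain. The compounds shown leave open whether chloro or methoxy on that aromatic carbon would lower the number as well, and whether fluoro on another carbon of the phenyl would do the same.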